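The source may report more compounds than this note shows. Statements on the series, on what has been measured and on what is new or still open speak of the compounds shown alone.

Of the compounds shown here, three built on one shared core have been tested in a functional assay on SAOS-2 cells (Homo sapiens) for antiproliferative activity, read by MTT assay, with a stated time of 72 h; a lower number here means a stronger inhibitor, a higher number a weaker inhibitor. Compound 1 `CCCCOC1=C(C(=O)c2ccccc2)C(c2ccc(Br)cc2)N(CCCn2ccnc2)C1=O` gives 11600 nM in this assay. Compound 2 `O=C(C1=C(OC2CCCCC2)C(=O)N(CCCn2ccnc2)C1c1ccc(Br)cc1)c1ccccc1`, which carries a cyclohexyl group in place of butyl on an oxygen on an unsaturated carbon, gives 29700 nM. Compound 3 `NC1=C(C(=O)c2ccccc2)C(c2ccc(Br)cc2)N(CCCn2ccnc2)C1=O`, in which an amino group replaces the butoxy group on a double-bonded ring carbon, gives 107000 nM, the highest of the three numbers and so the weakest inhibitor of the set. The change a 9.2-fold higher number from compound 1 to compound 3 (0.96 log units; beyond the scatter) and the change a 3.6-fold higher number from compound 2 to compound 3 (0.56 log units; beyond the scatter) both show the bare amino group giving a higher number than either alkoxy group, while the change a 2.6-fold higher number from compound 1 to compound 2 (0.41 log units; beyond the scatter) was smaller.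

Compound 4 `O=C(C1=C(Nc2ccccc2)C(=O)N(CCCn2ccnc2)C1c1ccc(Br)cc1)c1ccccc1` has not yet been measured. It differs from compound 3 by phenyl in place of hydrogen on an amine nitrogen, so that the amino group becomes an anilino group. Going by the values given here, no measured step adds a phenyl to that nitrogen, so the measured steps bear on it only indirectly: compound 1 and compound 2, the two alkoxy-bearing compounds, both gave lower numbers than compound 3, although the step from butoxy to cyclohexyloxy went the other way. The expected change is therefore a 2.7-fold lower number from compound 3 to compound 4 (0.43 log units; beyond the scatter), a modest move towards a lower number, with real uncertainty in both directions. The estimate for compound 4 in this assay is 40000 nM, with a range from 12000 nM to 130000 nM.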

Compound 4, half-maximal inhibitory concentration: 24400 nM
Compound 4: the middle estimate sits 1.6-fold (0.21 log units) above what was measured; the range from low to high includes it.
By their numbers in this assay, from the lowest: compound 1; then compounds 4 and 2 (each within the scatter of the next); then compound 3.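

In this assay, a phenyl on the amine nitrogen brings a 4.4-fold lower number from compound 3 to compound 4 (0.64 log units; beyond the scatter), so this nitrogen takes a six-carbon aromatic ring and the number falls rather than rises. The nitrogen link alone therefore does not tie this position to a high number: a 1.2-fold lower number from compound 2 to compound 4 (0.09 log units; within the scatter) lies within the scatter, which leaves anilino and cyclohexyloxy indistinguishable here, and only the bare amino group of compound 3 stands apart from the others by a clear margin. Anilino does not match butoxy, though, as a 2.1-fold higher number from compound 1 to compound 4 (0.32 log units; beyond the scatter) lies beyond the scatter, and compound 1 remains the strongest inhibitor of the four.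

No separate measurement is available to explain what the phenyl does at this position. The compounds shown leave open whether a butylamino or cyclohexylamino group would behave like its oxygen-linked counterpart, and whether a methoxy or chloro group on the anilino ring would move the number further.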